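A Methyl Replaces Chlorine on the Amide Aryl Ring

The source may report more compounds than this note shows. Statements on the series, on what has been measured and on what is new or still open speak of the compounds shown alone.

Three compounds share one core and differ only in the aryl group attached to the carbonyl carbon of the amide. Compound 1 `O=C(Nc1cc(Sc2ncn[nH]2)c(O)c2ccccc12)c1ccc([N+](=O)[O-])cc1` carries a 4-nitrophenyl group, compound 2 `O=C(Nc1cc(Sc2ncn[nH]2)c(O)c2ccccc12)c1ccc2ccccc2c1` a naphthalen-2-yl group, and compound 3 `O=C(Nc1cc(Sc2ncn[nH]2)c(O)c2ccccc12)c1ccc(Cl)cc1` a 4-chlorophenyl group. In a functional assay on MDA-MB-231 cells (Homo sapiens) for antiproliferative activity, read by MTT assay, with a stated time of 48 h (a lower number here means a stronger inhibitor, a higher number a weaker inhibitor), compound 1 gives > 100000 nM, which is a limit of the assay rather than a number (the limit of > 100000 nM in this assay, at which 1 of the 3 values shown sits). Compound 2 gives 45100 nM and compound 3 gives 25700 nM; the change a 1.8-fold lower number from compound 2 to compound 3 (0.24 log units; within the scatter) keeps these two on one level, while an at least 2.2-fold lower number from compound 1 to compound 2 (0.34 log units; beyond the scatter) and an at least 3.8-fold lower number from compound 1 to compound 3 (0.59 log units; beyond the scatter) both move away from the limit. Compound 4 `Cc1cccc(C(=O)Nc2cc(Sc3ncn[nH]3)c(O)c3ccccc23)c1` introduces (3-methylphenyl in place of 4-chlorophenyl on a carbonyl carbon). Among the compounds with values here, the one measured step that swaps the aryl group between two numbers, a 1.8-fold lower number from compound 2 to compound 3 (0.24 log units; within the scatter), stayed within the scatter, so a step of similar size or none at all is expected here. Compound 4 is estimated at 30000 nM, with a range from 12000 nM to 80000 nM. The expected step is a 1.2-fold higher number from compound 3 to compound 4 (0.07 log units; within the scatter).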

Compound 4, half-maximal inhibitory concentration: > 100000 nM
Compound 4: no number, only a limit; the forecaster's own chance of this, stated with the estimate: 15%; middle value at least 3.3-fold (0.52 log units) away from the limit.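

In this assay compound 4 gives > 100000 nM, which is a limit of the assay and not a number: the limit of > 100000 nM in this assay, at which 2 of the 4 values shown sit.

The earlier aryl swap between two measured numbers stayed within the scatter, but this position can also give a clear loss, with an at least 3.8-fold higher number from compound 3 to compound 4 (0.59 log units; beyond the scatter) and an at least 2.2-fold higher number from compound 2 to compound 4 (0.34 log units; beyond the scatter). The step between compound 1 and compound 4 cannot be read, as both are limits.

The change from 4-chlorophenyl to 3-methylphenyl alters both the group on the ring and its place, so the compounds shown cannot separate these two changes; 4-methylphenyl and 3-chlorophenyl would test each one alone. On these data alone, how far the true numbers of compound 1 and compound 4 lie past the limit also remains open.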